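A few compounds are considered here, and "the series" means these few. Any claim that something is new, unique, unknown or untested is made for them only; others in the source may bear on it.

Three compounds that share one core and differ only in the group on an aromatic nitrogen have so far been measured in a functional assay on A549 cells (Homo sapiens) for antiproliferative activity, read by MTT assay (a lower number here means a stronger inhibitor, a higher number a weaker inhibitor), for comparison. Compound 1 `CC1(C)CCc2cc(C(=O)/C=C/c3ccc(OCc4cn(-c5ccc(Br)cc5)nn4)cc3)c(O)cc2O1` gives 80000 nM as its value, compound 2 `Cc1c(-n2cc(COc3ccc(/C=C/C(=O)c4cc5c(cc4O)OC(C)(C)CC5)cc3)nn2)cccc1[N+](=O)[O-]` gives 65900 nM as its value, and compound 3 `CCc1ccccc1-n1cc(COc2ccc(/C=C/C(=O)c3cc4c(cc3O)OC(C)(C)CC4)cc2)nn1` gives 137000 nM as its value.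

Compound 3 shares the high end of this small set with compound 1: the gap is a 1.7-fold higher number from compound 1 to compound 3 (0.23 log units; within the scatter) on one side, while the other gap is a 2.1-fold higher number from compound 2 to compound 3 (0.32 log units; beyond the scatter) and counts as modest.

The next compound, compound 4 `CCCCCn1cc(COc2ccc(/C=C/C(=O)c3cc4c(cc3O)OC(C)(C)CC4)cc2)nn1`, carries pentyl in place of 2-ethylphenyl on an aromatic nitrogen and so has no ring in that group. The measured steps all exchange one ring-bearing group for another. One of them, a 1.2-fold lower number from compound 1 to compound 2 (0.08 log units; within the scatter), stayed within the scatter, and even the largest was small. Within the data shown here, no measured compound has a chain at this place, so these steps are only a rough guide.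

No step beyond the scatter is therefore expected in this assay for this change. Compound 3 at 137000 nM sits at the high end, so a slight lean to a lower number is expected. The expected change is a 1.7-fold lower number from compound 3 to compound 4 (0.23 log units; within the scatter) in size. For compound 4 the estimated value is 80000 nM with an expected range from 30000 nM to 180000 nM around it.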

Compound 4, half-maximal inhibitory concentration: 91300 nM
Compound 4: middle estimate off by 1.1-fold (0.06 log units), on the low side, within the range that was stated.
By their numbers in this assay, from the lowest: compounds 2, 1, 4 and 3 (each within the scatter of the next, the first and the last beyond it).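

Among these compounds, compound 4 is the first compound here with no ring in the group on the aromatic nitrogen, and exchanging a ring-bearing group for the pentyl chain still gives no step beyond the scatter in this assay. This holds against each of the three ring-bearing groups (a 1.5-fold lower number from compound 3 to compound 4 (0.18 log units; within the scatter)) (a 1.4-fold higher number from compound 2 to compound 4 (0.14 log units; within the scatter)) (a 1.1-fold higher number from compound 1 to compound 4 (0.06 log units; within the scatter)), so among these four compounds an aromatic ring in this group is not needed for a value in this range. No supporting measurement is available to explain this result at this position.

With pentyl as the only chain among the compounds shown, it remains open whether the length of the chain matters at all, and a longer chain such as decyl, or a shorter one such as ethyl, would address that. On these data alone, it also remains open whether any group on this nitrogen can move the number beyond the scatter, for example a chain ending in an amine or a carboxylic acid, which would place a very different kind of atom at the end of the group.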